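The source may report more compounds than this note shows. Statements on the series, on what has been measured and on what is new or still open speak of the compounds shown alone.

Compound 1 `Cc1nc(NC2CCC2)c2cc[nH]c2n1` gives 74100000 nM in a functional assay on the whole organism for inhibition, with Nicotiana tabacum as the target; a lower number here means a stronger inhibitor, a higher number a weaker inhibitor.
Compound 2 `Cc1nc(NC2CCCC2)c2cc[nH]c2n1` gives 72400000 nM in this assay.
Compound 3 `Cc1nc(NC(C)(C)O)c2cc[nH]c2n1` gives 166000000 nM in this assay.

Compound 3 has the highest number of the three and is the weakest inhibitor: the step of a 2.2-fold higher number from compound 1 to compound 3 (0.35 log units; beyond the scatter) and the step of a 2.3-fold higher number from compound 2 to compound 3 (0.36 log units; beyond the scatter) both lie beyond the scatter, while a 1.0-fold lower number from compound 1 to compound 2 (0.01 log units; within the scatter) lies within it. Compound 4 `Cc1nc(NCC2CC2)c2cc[nH]c2n1` is compound 3 with cyclopropylmethyl in place of 1-hydroxy-1-methylethyl on a nitrogen on an aromatic ring. This reverses the kind of change that separated compound 3 from compounds 1 and 2: the hydroxyl leaves and a carbon-only group returns to the nitrogen. Both earlier steps bear on this, each modest and in the same direction, so a modest lower number is expected for compound 4 in this assay, close to compounds 1 and 2. The expected step is a 2.2-fold lower number from compound 3 to compound 4 (0.35 log units; beyond the scatter). Compound 4 is estimated at 75000000 nM, with a range of 40000000 nM to 170000000 nM.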

Compound 4, half-maximal inhibitory concentration: 77600000 nM
The estimate for compound 4 lay 1.0-fold (0.01 log units) below the measured number; the range from low to high includes it.
By their numbers in this assay, from the lowest: compounds 2, 1 and 4 (each within the scatter of the next); then compound 3.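

Cyclopropylmethyl on this nitrogen reads the same as cyclopentyl (a 1.1-fold higher number from compound 2 to compound 4 (0.03 log units; within the scatter)) and cyclobutyl (a 1.0-fold higher number from compound 1 to compound 4 (0.02 log units; within the scatter)), so three different carbon-only groups now fall within the scatter of one another. Only compound 3, whose 1-hydroxy-1-methylethyl carries the oxygen, stands apart (a 2.1-fold lower number from compound 3 to compound 4 (0.33 log units; beyond the scatter)). No supporting measurement explains that gap.

Going by these compounds, whether the gap follows the oxygen itself or another feature of that group remains open. On these data alone, how an amine, a carboxylic acid or a longer carbon chain would read on this nitrogen also remains open.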